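Chain extension and cytotoxicity across two related cores

The source may hold more compounds than are shown below. What is called first, only, known or untested is meant among the compounds shown, and "the series" means these compounds.

Compound 1 `CCCc1ccc(C#Cc2cc3cn([C@H]4C[C@H](O)[C@@H](CO)O4)c(=O)nc3o2)cc1` and compound 2 `CCCCCc1ccc(C#Cc2cc3cn([C@H]4C[C@H](O)[C@@H](CO)O4)c(=O)nc3o2)cc1` share one core; compound 3 `CCCCc1ccc(-c2cc3cn([C@H]4C[C@H](O)[C@@H](CO)O4)c(=O)nc3o2)nc1` and compound 4 `CCCCCCc1ccc(-c2cc3cn([C@H]4C[C@H](O)[C@@H](CO)O4)c(=O)nc3o2)nc1` share another, and the difference between the two cores is not broken down here. In an ADME assay on HEL cells (Homo sapiens) for cytotoxicity, with a stated time of 3 days (on this read-out higher numbers stand for lower toxicity in this test and lower numbers for higher toxicity in this test), compound 1 gives 87000 nM and compound 2 gives 470000 nM. The change ethyl in place of hydrogen on a saturated chain carbon, three bonds along the chain from an aromatic carbon gave a 5.4-fold higher number from compound 1 to compound 2 (0.73 log units; beyond the scatter). For compound 3 this assay reports only a limit, > 100000 nM, in line with the limit of > 100000 nM in this assay, at which 1 of the 3 values shown sits. The change to compound 4, (ethyl in place of hydrogen on a saturated chain carbon, four bonds along the chain from an aromatic carbon), is the same kind of change, differing only in that it sits four bonds along the chain from an aromatic carbon rather than three. Resting on the measured step of a 5.4-fold higher number from compound 1 to compound 2 (0.73 log units; beyond the scatter), a step that the limit leaves unreadable from compound 3 to compound 4 is expected. Compound 4 is estimated at 300000 nM, with a real chance that this assay again returns only a limit.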

Compound 4, minimum cytotoxic concentration: > 100000 nM
Compound 4: no number, only a limit; the forecaster's own chance of this, stated with the estimate: 60%; the middle value is on the limit's open side.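

Compound 4 gives only a limit in this assay, > 100000 nM, so no step from compound 3, also a limit, can be read: the limit of > 100000 nM in this assay, at which 2 of the 4 values shown sit.

Going by these compounds, whether chain extension on the core of compound 3 raises the number, as on the core of compound 1, stays open.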